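The compounds below may be only part of what the source reports. "The series", "measured", "known", "first", "only" and "open" are said of these compounds alone.

Measured compounds in an assay on isolated protein for inhibition of RAC-alpha serine/threonine-protein kinase (Homo sapiens), read by 33P incorporation, in the presence of a further agent that is not named here; on this read-out lower numbers stand for stronger inhibition and higher numbers for weaker inhibition:
Compound 1 `CNc1ncc2c(-c3ccc(N4CCNCC4)nc3)nn(CC3OCCO3)c2n1` gives > 10000 nM, which is a limit of the assay.
Compound 2 `CNc1ncc2c(-c3ccc(N4CCNCC4)nc3)nn(Cc3cn(Cc4ccccc4)nn3)c2n1` gives > 10000 nM, also only a limit.
Compound 3 `CNc1ncc2c(-c3ccc(N4CCNCC4)nc3)nn(Cc3cn(-c4ccsc4C(=O)OC)nn3)c2n1` gives > 10000 nM, again a limit.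

Compound 2 therefore stands at the limit of > 10000 nM in this assay, at which 3 of the 3 values shown sit, with no number of its own. The change to compound 4 `CNc1ncc2c(-c3ccc(N4CCN(C)CC4)nc3)nn(Cc3cn(Cc4ccccc4)nn3)c2n1` is methyl in place of hydrogen on an amine nitrogen in a ring, with the piperazin-1-yl becoming 4-methylpiperazin-1-yl. The measured steps a step that the two limits leave unreadable from compound 1 to compound 2 and a step that the two limits leave unreadable from compound 2 to compound 3 both start or end at this limit and cannot be sized, so no direction can be read from them. With all three values sitting at the limit, compound 4 is estimated at 15000 nM, within 5000 nM to 50000 nM. The step that the limit leaves unreadable from compound 2 to compound 4 is thus expected to be unreadable rather than a change beyond the scatter.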

Compound 4, half-maximal inhibitory concentration: > 10000 nM
Compound 4: no number, only a limit; the forecaster's own chance of this, stated with the estimate: 85%; the middle value does not contradict the limit.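

Compound 4 gives > 10000 nM, which is a limit of the assay. Compound 2 sits at the same limit, so no step can be read from compound 2 to compound 4. The compounds shown leave open how strongly any of them inhibits the kinase: none has a number of its own.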